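Swapping a Carbamoyl for an Amino Group on Compound 1

The source may hold more compounds than are shown below. What is called first, only, known or untested is meant among the compounds shown, and "the series" means these compounds.

Of the compounds shown here, two have so far been measured in an assay for inhibition of MAP kinase-interacting serine/threonine-protein kinase 2 (Homo sapiens), read by luminescence and ADP-Glo, with a stated time of 2 h; on this read-out lower numbers stand for stronger inhibition and higher numbers for weaker inhibition. Compound 1 `NC(=O)c1cccc(Cn2cc(-c3ccc4cn[nH]c4c3)ccc2=O)c1` gives 106 nM in this assay. Compound 2 `O=c1ccc(-c2n[nH]c3ncc(Br)cc23)cn1Cc1ccccc1` gives 12 nM in this assay. Of these two numbers, compound 1 has the higher one, and compound 2 sits at a lower number by a gap beyond the usual scatter of repeated measurements. The untested compound 3 `Nc1cccc(Cn2cc(-c3ccc4cn[nH]c4c3)ccc2=O)c1` keeps the whole frame of compound 1 and changes a single point: amino in place of carbamoyl on an aromatic carbon. Among the measured compounds shown here, no measured pair differs in exactly this way, so there is no direct step to lean on; compound 2 differs from compound 1 in several places at once and cannot show what this one change does. The expected step is a 1.9-fold higher number from compound 1 to compound 3 (0.28 log units; within the scatter), a small move toward weaker inhibition that may stay within the scatter. Compound 3 is therefore estimated at 200 nM in this assay, with a likely range from 60 nM to 700 nM.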

Compound 3, half-maximal inhibitory concentration: 84 nM
Beside the measured number, compound 3's estimate is 2.4-fold (0.38 log units) above it, and the stated range covers the measured number.
By their numbers in this assay, from the lowest: compound 2; then compounds 3 and 1 (each within the scatter of the next).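

In this assay the swap of carbamoyl for amino on this aromatic carbon gives a 1.3-fold lower number from compound 1 to compound 3 (0.10 log units; within the scatter) and so leaves the number where the scatter cannot separate the two compounds. For this one pair, then, the carbonyl carbon and oxygen of the carbamoyl group are not needed to hold the number at this place, meta to a large group, as long as an amino group stays there. Nothing available explains why the two groups read alike in this assay.

Still open, on these data alone, is whether this tolerance extends to other groups at the same place, such as a carboxylic acid, a hydroxyl or a longer chain like aminomethyl. It is also unclear whether an amino group at another carbon of this ring would read the same.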